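This account rests on a few compounds, and the source may have more. Where it says the series, first, only, none or still open, it means among the compounds named here.

Of the compounds shown here, two have been measured in a physicochemical assay for solubility, in phosphate buffer, at pH 7.4; a higher number here means a more soluble compound, a lower number a less soluble compound. Compound 1, `CC(=O)N1CCC(c2cc3c(-c4ccc(=O)n(C(C)C)c4)ccnc3[nH]2)CC1`, gives 27000 nM, the lower of the two numbers. Compound 2, `CC(C)Cn1cc(-c2ccnc3[nH]c(C4CCN(CC(=O)N(C)C)CC4)cc23)ccc1=O`, gives 390000 nM, a step up from compound 1 that lies well beyond the scatter of this assay.

The next compound, compound 3, `CNC(=O)CN1CCC(c2cc3c(-c4ccc(=O)n(C(C)C)c4)ccnc3[nH]2)CC1`, is built from compound 1 with a single change: (methylcarbamoyl)methyl in place of acetyl on an amine nitrogen in a ring. For the measured compounds named here, no measured pair shows this exact change, so the expected size of the step is a guess rather than a reading. Given that compound 2 gives 390000 nM, a large upward step is expected, with the risk that compound 3 instead stays close to compound 1.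

On that basis compound 3 is expected to give 200000 nM in this assay, within a range from 50000 nM to 500000 nM, an expected step of a 7.4-fold higher number from compound 1 to compound 3 (0.87 log units; beyond the scatter).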

Compound 3, solubility: 34000 nM
Compound 3: the middle estimate sits 5.9-fold (0.77 log units) above what was measured; the whole stated range lies above it.
By their numbers in this assay, from the lowest: compounds 1 and 3 (each within the scatter of the next); then compound 2.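

In this assay, exchanging the acetyl group for (methylcarbamoyl)methyl gives a 1.3-fold higher number from compound 1 to compound 3 (0.10 log units; within the scatter), so this exchange does not separate the two compounds. That holds even though the entering group is larger and counts 1 hydrogen-bond donor, while the leaving acetyl counts none. No measurement to hand accounts for this result.

Compound 3 differs from compound 2 in more than one place, so compound 2 with its 390000 nM cannot be tied to any single change. Also open, going by these compounds, is whether a carboxylic acid or a longer chain ending in an amine, placed on this same ring nitrogen, would give a step beyond the scatter.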